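The source may report more compounds than this note shows. Statements on the series, on what has been measured and on what is new or still open speak of the compounds shown alone.

In a functional assay on J774 cells (Mus musculus) for cytotoxicity, read by resazurin assay (on this read-out higher numbers stand for weaker inhibition and lower numbers for stronger inhibition), compound 1 (`OCCCCCC(O)c1ccc(-c2ccc(Br)cc2)cc1`) gives 20000 nM while compound 2 (`O=C(CCCCCO)c1ccc(-c2ccc(F)cc2F)cc1`) gives 6000 nM and compound 3 (`Cc1cc(C(=O)CCCCCO)ccc1-c1ccc(F)cc1F`) gives 8000 nM on the same read-out. Compound 2 stands at the low end of these numbers, within the scatter of compound 3 and clearly apart from compound 1. Compound 4 (`Cc1cc(-c2ccc(F)cc2F)ccc1C(=O)CCCCCO`) differs from compound 2 by methyl in place of hydrogen on an aromatic carbon in one place, methyl in place of hydrogen on an aromatic carbon. Among the measured compounds shown here, the only measured step of that kind is a 1.3-fold higher number from compound 2 to compound 3 (0.12 log units; within the scatter) and it puts the methyl on another aromatic carbon. One such step is thin evidence, but no step beyond the scatter is expected in this assay for this change. The step expected is a 1.2-fold higher number from compound 2 to compound 4 (0.07 log units; within the scatter) at this stage. For compound 4 the estimate is 7000 nM with an expected range of 3000 nM to 16000 nM in this measurement.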

Compound 4, half-maximal inhibitory concentration: 4000 nM
The estimate for compound 4 lay 1.8-fold (0.24 log units) above the measured number; the range from low to high includes it.
By their numbers in this assay, from the lowest: compounds 4, 2 and 3 (each within the scatter of the next); then compound 1.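

In this assay methyl in place of hydrogen on this aromatic carbon gives a 1.5-fold lower number from compound 2 to compound 4 (0.18 log units; within the scatter) and so stays within the scatter. The other methyl placement, a 1.3-fold higher number from compound 2 to compound 3 (0.12 log units; within the scatter) on the same scale, also stays within it, so neither of these two carbons shows a clear change with this small group. Nothing measured here offers any explanation for these steps. Still open, as far as these compounds go, is whether an ethyl group, a methoxy group or an amine on this carbon would move the number beyond the scatter.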